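From compound 2 to compound 4: one sulfonyl group changed

The source may hold more compounds than are shown below. What is called first, only, known or untested is meant among the compounds shown, and "the series" means these compounds.

In a functional assay on HT-29 cells (Homo sapiens) for cytotoxicity, read by resazurin assay, with a stated time of 48 h (a higher number here means that more compound is needed for the effect, a lower number that less compound is needed), compound 1 (`O=S(=O)(Nc1ccc(-c2nc3cc(NS(=O)(=O)c4ccccc4Cl)ccc3o2)cc1)c1ccccc1Cl`) gives 15000 nM and compound 3 (`O=S(=O)(Nc1ccc(-c2nc3cc(NS(=O)(=O)c4ccc(Br)cc4)ccc3o2)cc1)c1ccc(Br)cc1`) gives 17000 nM on the same read-out. Compound 2 (`O=S(=O)(Nc1ccc(-c2nc3cc(NS(=O)(=O)c4ccc(Cl)s4)ccc3o2)cc1)c1ccc(Cl)c(C(F)(F)F)c1`) gives 21000 nM and so stands within the scatter of both compound 1 and compound 3; the three numbers cannot be put in order. These compounds share a core and carry different groups on their sulfonyl sulfurs, yet their values do not separate.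

The next structure is compound 4 (`O=S(=O)(Nc1ccc(-c2nc3cc(NS(=O)(=O)c4ccc(Cl)s4)ccc3o2)cc1)c1ccc(Cl)s1`), which has 5-chlorothiophen-2-yl in place of the 4-chloro-3-(trifluoromethyl)phenyl of compound 2 on a sulfonyl sulfur (5-chlorothiophen-2-yl in place of 4-chloro-3-(trifluoromethyl)phenyl on a sulfonyl sulfur). Going by the values given here, no pair of measured compounds differs in only one place, so this change has no direct precedent in the data. The expectation rests instead on the narrow spread of the measured values, with compound 1 at 15000 nM and compound 2 at 21000 nM still within the scatter of each other. The estimated 1.2-fold lower number from compound 2 to compound 4 (0.07 log units; within the scatter) is expected to stay within the scatter in this assay and to show no clear direction. Compound 4 is estimated at 18000 nM (expected range 9000 nM to 35000 nM).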

Compound 4, half-maximal effective concentration: 33000 nM
Beside the measured number, compound 4's estimate is 1.8-fold (0.26 log units) below it; measured number inside the range.
By their numbers in this assay, from the lowest: compounds 1, 3, 2 and 4 (each within the scatter of the next, the first and the last beyond it).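

In this assay, going by these compounds alone, the replacement of 4-chloro-3-(trifluoromethyl)phenyl by 5-chlorothiophen-2-yl on a sulfonyl sulfur comes with a 1.6-fold higher number from compound 2 to compound 4 (0.20 log units; within the scatter), and this is the first pair that differs in only one place. The earlier compounds shown here differ from one another in more than one place, so they could not isolate any single group, whereas this pair shows that a five-membered aromatic ring with 1 hetero atom and a six-membered aromatic ring of carbon only, which has more heavy atoms, are not told apart at this position. No measurement offered here accounts for the result, and it stands as an observation only.

This single step does not show whether the same replacement would read alike with a different group on the other sulfonyl sulfur of the shared core. It also leaves open how the read-out responds when a sulfonyl sulfur carries a group of another kind, such as a longer alkyl chain, an amine or a carboxylic acid.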